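Adding a Second Chloro: Cytotoxicity Limits Across Two Cores

The source may hold more compounds than are shown below. What is called first, only, known or untested is meant among the compounds shown, and "the series" means these compounds.

In an ADME assay on BJ cells (Homo sapiens) for cytotoxicity, with a stated time of 72 h (on this read-out lower numbers stand for an effect already at smaller amounts and higher numbers for an effect only at larger amounts of compound), compound 1, `C=C[C@@](C)(/C=C/c1ccc(O)c(/C=C/c2ccc(Cl)cc2)c1)CCC=C(C)C`, gives > 36600 nM, which is a limit of the assay and not a number. Compound 2, `C=C[C@@](C)(/C=C/c1ccc(O)c(/C=C/c2ccc(Cl)c(Cl)c2)c1)CCC=C(C)C`, differs from compound 1 by chloro in place of hydrogen on an aromatic carbon. In this assay compound 2 gives > 13000 nM, again a limit. The step that the two limits leave unreadable from compound 1 to compound 2 stays unreadable due to the limit of > 13000 nM in this assay, at which 1 of the 3 values shown sits, and (the limit of > 36600 nM in this assay, at which 2 of the 3 values shown sit), so nothing can be said about whether the extra chloro shifted cytotoxicity. Compound 3, `C=C[C@@](C)(/C=C/c1ccc(Nc2ccc(Cl)cc2)cc1)CCC=C(C)C`, rests on a different core; the difference between the two cores is not broken down here. In this assay compound 3 gives > 36600 nM, a limit. Going by the values given here, compound 4, `C=C[C@@](C)(/C=C/c1ccc(Nc2ccc(Cl)c(Cl)c2)cc1)CCC=C(C)C`, has not yet been measured; it differs from compound 3 by chloro in place of hydrogen on an aromatic carbon, the same change as the one from compound 1 to compound 2, made at the same kind of place. The step that the limit leaves unreadable from compound 3 to compound 4 is expected to be small, resting on compound 3 with > 36600 nM and on the unreadable earlier step. Compound 4 is therefore estimated at about 40000 nM, most likely again reported only as a limit.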

Compound 4, half-maximal effective concentration: > 36600 nM
Compound 4: no number, only a limit (the forecaster's own chance of this, stated with the estimate: 85%); the middle value does not contradict the limit.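

Compound 4 gives > 36600 nM in this assay, which is a limit of the assay and not a number. Compound 3 also stands only at a limit, so no step between compound 3 and compound 4 can be read: the limit of > 36600 nM in this assay, at which 3 of the 4 values shown sit.

The compounds shown leave open whether the added chloro changes cytotoxicity at all, on either core.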